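This account rests on a few compounds, and the source may have more. Where it says the series, first, only, none or still open, it means among the compounds named here.

Compound 1 `Cc1noc(-c2nc(C)c3c(c2N)C(=O)N(Cc2ccccc2C(F)(F)F)C3=O)n1` gives < 5000 nM
Compound 2 `Cc1noc(-c2nc(C)c3c(c2N)C(=O)N(Cc2ccc(S(C)(=O)=O)cc2)C3=O)n1` gives < 5000 nM
Compound 3 `Cc1noc(-c2nc(C)c3c(c2N)C(=O)N(Cc2ccc(SC(F)(F)F)cc2)C3=O)n1` gives < 5000 nM

These readings come from a physicochemical assay for solubility, using the shake flask method, in simulated intestinal fluid, measured as kinetic solubility, with a stated time of 2 h, at 25 degrees C, at pH 6.5 (a lower number here means a less soluble compound, a higher number a more soluble compound), and each one is a limit of the assay, not a number. Compound 3 therefore has no exact position. It stands at the limit of < 5000 nM in this assay, at which 3 of the 3 values shown sit, and cannot be ranked against compound 1 or compound 2.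

The next compound is compound 4 `Cc1noc(-c2nc(C)c3c(c2N)C(=O)N(Cc2ccc(CO)cc2)C3=O)n1` which carries hydroxymethyl in place of (trifluoromethyl)sulfanyl on an aromatic carbon of a six-membered aromatic ring of carbon only, para to a large group. The counted difference is hydroxymethyl in place of (trifluoromethyl)sulfanyl on an aromatic carbon and the rest of the structure stays the same.

Within the data shown here, two measured steps bear on this change, and neither has a usable size. The closer one is a step that the two limits leave unreadable from compound 2 to compound 3 and it also swaps a group on an aromatic carbon. The other is a step that the two limits leave unreadable from compound 1 to compound 2 and it adds no further guidance. With no size to carry over, no direction can be argued, and no step beyond the scatter is expected in this assay for this swap. The expected change is a step that the limit leaves unreadable from compound 3 to compound 4 and this remains a rough estimate. For compound 4 the estimated solubility is 4000 nM with an expected range of 1000 nM to 15000 nM and the assay may well report only a limit again.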

Compound 4, solubility: < 5000 nM
Compound 4 ended at the assay's limit; the forecaster's own chance of this, stated with the estimate: 65%; the middle value does not contradict the limit.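

In this assay, among these compounds, compound 4 gives only a limit, so no step from compound 1, compound 2 or compound 3 to compound 4 can be read, and all four compounds share one reading: the limit of < 5000 nM in this assay, at which 4 of the 4 values shown sit. The compounds shown leave open how soluble each one really is, and whether the group swaps among them make any difference.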